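Shortening the side chain of a weak inhibitor

The compounds below may be only part of what the source reports. "The series", "measured", "known", "first", "only" and "open" are said of these compounds alone.

In a functional assay on PC-12 cells (Rattus norvegicus) for inhibition, read by sulforhodamine B assay (a lower number here means a stronger inhibitor, a higher number a weaker inhibitor), compound 1 `O=C1NC(=O)C(Cc2ccc(OCC3CCCCO3)cc2)S1` gives > 100000 nM as a limit of the assay, not a number. For the measured compounds named here, compound 2 `CC(C)COc1ccc(CC2SC(=O)NC2=O)cc1` at 25000 nM holds the only actual number so far. Compound 3 `CCOc1ccc(CC2SC(=O)NC2=O)cc1`, still unmeasured, has methyl in place of isopropyl on a saturated chain carbon bound to an oxygen on an aromatic ring. Going by the values given here, the only measured step at that place (an at least 4.0-fold lower number from compound 1 to compound 2 (0.60 log units; beyond the scatter)) put isopropyl in place of oxan-2-yl, a different swap that sets no firm direction. In this assay no step beyond the scatter is therefore expected (a 1.2-fold higher number from compound 2 to compound 3 (0.08 log units; within the scatter)). For compound 3 the estimate is 30000 nM (expected range 9000 nM to 100000 nM).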

Compound 3, half-maximal inhibitory concentration: > 100000 nM
Compound 3 ended at the assay's limit; the forecaster's own chance of this, stated with the estimate: 20%; at least 3.3-fold (0.52 log units) between middle value and limit.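

In this assay, replacing isopropyl with methyl gives an at least 4.0-fold higher number from compound 2 to compound 3 (0.60 log units; beyond the scatter), so this small change at the chain end is not neutral. Compound 2 now stands as stronger than both neighbours: the larger oxan-2-yl of compound 1 and the smaller methyl of compound 3 each give a weaker result. The step between compound 1 and compound 3 cannot be read, as both values are limits rather than numbers: the limit of > 100000 nM in this assay, at which 2 of the 3 values shown sit.

On these data alone, whether a chain longer than isobutyl, or an amine at this place, would give a lower number remains open.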